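Relocating a Ring Nitrogen: From Compound 3 to Compound 4

The compounds below may be only part of what the source reports. "The series", "measured", "known", "first", "only" and "open" are said of these compounds alone.

Of the compounds shown here, three built on one shared core have been measured in an assay on COS-7 cells for inhibition of tyrosine-protein kinase receptor UFO (Homo sapiens), read by ELISA, with a stated time of 1 h; on this read-out lower numbers stand for stronger inhibition and higher numbers for weaker inhibition. Compound 1 `Cc1cc(-c2c(C)nn(C)c2C)cnc1-c1nnc(N(C)Cc2ccc3ncc(-c4cnn(CCN(C)C)c4)n3c2)o1` gives 1000 nM in this assay. Compound 2 `Cc1cc(-c2c(C)nn(C)c2C)cnc1-c1nnc(N(C)Cc2ccc3ncc(-c4cccc(CN(C)C)c4)n3c2)o1` gives 316 nM, and compound 3 `Cc1cc(-c2c(C)nn(C)c2C)cnc1-c1nnc(N(C)Cc2ccc3ncc(-c4ccc(CN(C)C)nc4)n3c2)o1` gives 1580 nM. Compound 3 therefore stands at the highest number of the three, but its gap to compound 1 is within the scatter (a 1.6-fold higher number from compound 1 to compound 3 (0.20 log units; within the scatter)), whereas the step of a 5.0-fold higher number from compound 2 to compound 3 (0.70 log units; beyond the scatter) lies beyond it. Among the compounds with values here, the only other step, a 3.2-fold lower number from compound 1 to compound 2 (0.50 log units; beyond the scatter), also points to the phenyl-bearing compound 2 as the one with the lowest number.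

Compound 4 `Cc1cc(-c2c(C)nn(C)c2C)cnc1-c1nnc(N(C)Cc2ccc3ncc(-c4ccc(CN(C)C)cn4)n3c2)o1` differs from compound 3 by 5-((dimethylamino)methyl)pyridin-2-yl in place of 6-((dimethylamino)methyl)pyridin-3-yl on an aromatic carbon. None of the three measured steps moves a nitrogen within a ring of the same type; each exchanges one kind of ring for another. The two steps that involve the pyridinyl of compound 3 reached it from a pyrazolyl within the scatter and from a phenyl beyond it, so they give no direct guide to a change of nitrogen position. The expectation for compound 4 is thus a step of a 1.1-fold lower number from compound 3 to compound 4 (0.05 log units; within the scatter), within the scatter. The estimate for compound 4 in this assay is 1400 nM, ranging from 450 nM to 4500 nM.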

Compound 4, half-maximal inhibitory concentration in the tyrosine-protein kinase receptor UFO assay: 126 nM
Compound 4: the middle estimate sits 11-fold (1.05 log units) above what was measured; the measured number lies below the stated range.
By their numbers in the tyrosine-protein kinase receptor UFO assay, from the lowest: compound 4; then compound 2; then compounds 1 and 3 (each within the scatter of the next).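

The step from the pyridin-3-yl to the pyridin-2-yl attachment keeps the same atoms and the same counts, yet in the tyrosine-protein kinase receptor UFO assay it gives a 13-fold lower number from compound 3 to compound 4 (1.10 log units; beyond the scatter), so on this aromatic carbon the arrangement of one pyridine ring can matter as much as the exchanges of ring type seen earlier, or more. The 5-((dimethylamino)methyl)pyridin-2-yl group also outdoes both other groups in the tyrosine-protein kinase receptor UFO assay, with a 2.5-fold lower number from compound 2 to compound 4 (0.40 log units; beyond the scatter) and a 7.9-fold lower number from compound 1 to compound 4 (0.90 log units; beyond the scatter), which leaves compound 4 with the lowest number of the four, beyond the scatter of each of the others. The same change also shifts the reading in a physicochemical assay for lipophilicity, at pH 7.4 (on this read-out higher numbers stand for higher lipophilicity and lower numbers for lower lipophilicity), showing that the two isomeric groups differ in a measured property as well: the measured distribution coefficient of compound 3, 2.5, and of compound 4, 3, a number 0.50 log units higher (beyond the scatter)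

A single pair cannot tell whether the shifts in the two assays are linked, since the physicochemical assay is shown only for compound 3 (2.5) and compound 4 (3). The compounds shown also leave open whether the 5-((dimethylamino)methyl)pyridin-2-yl group would keep its number in the tyrosine-protein kinase receptor UFO assay with a pyrrolidine or a morpholine in place of the dimethylamine, or with a longer chain to the amine.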